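Replacing Butyl with 4-Pentylphenyl on an Inactive Alkyne

The compounds below may be only part of what the source reports. "The series", "measured", "known", "first", "only" and "open" are said of these compounds alone.

Compound 1 `CCCCC#Cc1cn(C/C=C\CN2C(=O)c3ccccc3C2=O)c(=O)[nH]c1=O` gives 82000 nM in a functional assay on SW-620 cells (Homo sapiens) for antiproliferative activity, read by MTT assay, with a stated time of 3 days; a lower number here means a stronger inhibitor, a higher number a weaker inhibitor.
Compound 2 `O=C1c2ccccc2C(=O)N1C/C=C\Cn1cc(C#Cc2ccc(Br)cc2)c(=O)[nH]c1=O` reaches only the limit of this assay, > 100000 nM.
Compound 3 `CCCCC#Cc1cn(C/C=C/CN2C(=O)c3ccccc3C2=O)c(=O)[nH]c1=O` also reaches only the limit of this assay, > 100000 nM.

Compound 3 therefore stands at the weak end of what this assay can report, with no number of its own, a position it shares with compound 2 (the limit of > 100000 nM in this assay, at which 2 of the 3 values shown sit). Compound 4 `CCCCCc1ccc(C#Cc2cn(C/C=C/CN3C(=O)c4ccccc4C3=O)c(=O)[nH]c2=O)cc1` arises from compound 3 by one change: 4-pentylphenyl in place of butyl on a triple-bonded carbon. Among the compounds with values here, two measured steps bear on this. The closest is an at least 1.2-fold higher number from compound 1 to compound 2 (0.08 log units; that floor lies within the scatter), a swap of an aryl group for butyl on the same triple-bonded carbon, which moved toward a higher number without leaving the scatter. The other is an at least 1.2-fold higher number from compound 1 to compound 3 (0.08 log units; that floor lies within the scatter), showing that the isomer drawn E is itself at the limit (the fact that compounds 1 and 3 differ only in the configuration as drawn). Neither gives a reason to expect a lower number, so compound 4 is expected to remain at the limit, with a step that the limit leaves unreadable from compound 3 to compound 4 at most within the scatter. Compound 4 is estimated at 150000 nM, in a range of 60000 nM to 400000 nM.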

Compound 4, half-maximal inhibitory concentration: 30000 nM
Estimate against measurement, compound 4: 5.0-fold (0.70 log units) above; the whole stated range lies above it.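

Within the data shown here, putting 4-pentylphenyl on this triple-bonded carbon gives an at least 3.3-fold lower number from compound 3 to compound 4 (0.52 log units; beyond the scatter) in this assay, the first step in this set that is beyond the scatter, so the group held here can change the antiproliferative reading. The earlier aryl swap, an at least 1.2-fold higher number from compound 1 to compound 2 (0.08 log units; that floor lies within the scatter), gave no sign of this, so an aryl group on this carbon does not guarantee a lower number. The true size of the new step remains unknown, and its printed size is only a floor, since compound 3 has no number of its own: the limit of > 100000 nM in this assay, at which 2 of the 4 values shown sit.

Going by these compounds, whether the lower number comes from the aromatic ring or from the pentyl chain stays open, as does whether it holds with the double bond drawn Z. A plain phenyl group or a 4-octylphenyl group on the same carbon would help separate the ring from the chain.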